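The compounds below may be only part of what the source reports. "The series", "measured", "known", "first", "only" and "open" are said of these compounds alone.

Compound 1 `COc1ccc(-c2cn(C/C=C3\OC(=O)C(OCc4ccccc4)=C3OCc3ccccc3)nn2)cc1`: in an ADME assay on HFF cells (Homo sapiens) for cytotoxicity, read by MTT assay, with a stated time of 72 h (on this read-out lower numbers stand for stronger inhibition and higher numbers for weaker inhibition), compound 1 gives > 100000 nM, which is a limit of the assay rather than a number.
Compound 2 `O=C1O[C@H]([C@@H](O)Cn2cc(CNS(=O)(=O)c3ccc(Cl)cc3F)nn2)C(OCc2ccccc2)=C1OCc1ccccc1`: in this assay compound 2 gives 20 nM.

Compound 2 holds the only number shown; the other value is a limit (the limit of > 100000 nM in this assay, at which 1 of the 2 values shown sits). Compound 3 `O=C1O[C@H]([C@@H](O)Cn2cc(CCO)nn2)C(OCc2ccccc2)=C1OCc1ccccc1` is not yet measured. It differs from compound 2 by hydroxymethyl in place of ((4-chloro-2-fluorophenyl)sulfonyl)amino on a saturated chain carbon bound to an aromatic carbon. For the measured compounds named here, no measured step with a single change exists for comparison. The loss of the larger group is expected to weaken inhibition by compound 3 in this assay, with a step estimated as a 250-fold higher number from compound 2 to compound 3 (2.40 log units; beyond the scatter). For compound 3 the expected value is 5000 nM, between 500 nM and 100000 nM.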

Compound 3, half-maximal inhibitory concentration: 58500 nM
The estimate for compound 3 lay 12-fold (1.07 log units) below the measured number; measured number inside the range.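

In this assay, hydroxymethyl in place of ((4-chloro-2-fluorophenyl)sulfonyl)amino on a saturated chain carbon bound to an aromatic carbon brings a 2900-fold higher number from compound 2 to compound 3 (3.47 log units; beyond the scatter). This first single-change step shows that the read-out depends strongly on the group at this place, with the core left unchanged. No measurement shown gives a cause for the step. One step cannot tell whether the aromatic ring, the sulfonyl or the amino nitrogen carries the effect. From the compounds shown here alone, whether an amine or a carboxylic acid here would read closer to compound 2 or compound 3 also remains open.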